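The source may hold more compounds than are shown below. What is called first, only, known or untested is meant among the compounds shown, and "the series" means these compounds.

Of the compounds shown here, three that share one core have been tested in a functional assay on the whole organism (plasma, strain albino) for inhibition, with Rattus norvegicus as the target, with stated times of 1 h and 4 h, at a dose of 50 mg/kg by the oral route; a higher number here means a stronger effect of the compound at the dose given, a lower number a weaker effect. Compound 1, `COc1ccc(C2CC(c3ccc(NC(=O)c4cc(Cl)ccc4OC)cc3)=NN2C)cc1`, gives 81.8% in this assay. Compound 2, `COc1ccc(Cl)cc1C(=O)Nc1ccc(C2=NN(C)C(c3ccccc3[N+](=O)[O-])C2)cc1`, gives 91.3%, and compound 3, `COc1ccc(Cl)cc1C(=O)Nc1ccc(C2=NN(C)C(c3ccc([N+](=O)[O-])cc3)C2)cc1`, gives 83.2%. Compound 1 stands at the lowest of the three numbers, yet its steps to the other two are small: a number 9.5 percentage points higher from compound 1 to compound 2 (within the scatter), and a number 1.4 percentage points higher from compound 1 to compound 3 (within the scatter). The step between the other two, a number 8.1 percentage points lower from compound 2 to compound 3 (within the scatter), is also small, so the three compounds cannot be told apart on these numbers.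

Compound 4, `COc1ccc(C2CC(c3ccc(NC(=O)c4cc(Cl)ccc4OC)cc3)=NN2c2ccccc2)cc1`, has not yet been measured. It differs from compound 1 in one place: phenyl in place of methyl on an amine nitrogen in a ring. All three measured steps concern the group on a saturated ring carbon, not the group on the ring nitrogen, so none of them bears directly on this change. What they do show is that the core tolerates changes at the neighbouring position without moving the read-out beyond the scatter. Within the data shown here, with no measured step for the ring-nitrogen position, no step beyond the scatter in this assay is expected for compound 4. Compound 4 is therefore expected to give about 82%, within a range from 65% to 95%. That estimate means a step of a number 0.2 percentage points higher from compound 1 to compound 4 (within the scatter) is expected.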

Compound 4, a percentage reported as inhibition, in the whole organism at one dose (the size of the read-out at that dose, not a potency): 90.2%
Beside the measured number, compound 4's estimate is 8.2 percentage points below it; the measured number falls inside the stated range.
By their numbers in this assay, from the lowest: compounds 1, 3, 4 and 2 (each within the scatter of the next).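

Among these compounds, compound 4 gives the first look at the amine nitrogen in the ring: in this assay, placing phenyl there instead of methyl gives a number 8.4 percentage points higher from compound 1 to compound 4 (within the scatter) and brings in a six-membered aromatic ring of carbon only where a single carbon stood. Even with this much bigger group, the read-out stays within the usual scatter, so the shared core tolerates the exchange in this whole-animal test, although a result at one dose reflects the size of the effect and not potency. Nothing available explains why the read-out holds at this position.

The compounds shown place only methyl and phenyl on this nitrogen, which leaves open how a longer chain such as butyl, a benzyl group, an acetyl group or a phenyl carrying a nitro group would behave there. They also leave open what happens when phenyl on the nitrogen is combined with 2-nitrophenyl or 4-nitrophenyl in place of the 4-methoxyphenyl group on the neighbouring ring atom.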